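The source may report more compounds than this note shows. Statements on the series, on what has been measured and on what is new or still open speak of the compounds shown alone.

Measured so far:
compound 1 `Cc1ccccc1N(C)C(=O)c1ccc(-c2ccc(O)cc2)o1` — 21 nM
compound 2 `Cc1ccccc1N(C)C(=O)c1ccc(-c2cccc(O)c2)o1` — 29 nM

In an assay on T47D cells for inhibition of 17-beta-hydroxysteroid dehydrogenase type 1 (Homo sapiens), read by HPLC, with a stated time of 24 h (a higher number here means a weaker inhibitor, a lower number a stronger inhibitor), compound 2 gives the higher of the two numbers, though its nearest neighbour compound 1 lies within the scatter of it, as the step of a 1.4-fold higher number from compound 1 to compound 2 (0.14 log units; within the scatter) shows. Compound 3 `Cc1ccccc1N(C)C(=O)c1ccc(-c2ccccc2O)o1` is not yet measured; it differs from compound 2 by 2-hydroxyphenyl in place of 3-hydroxyphenyl on an aromatic carbon. For the measured compounds named here, only the step from compound 1 to compound 2 bears on this change, and it was within the scatter. A modest move toward a higher number, barely beyond the scatter, is expected: a 1.9-fold higher number from compound 2 to compound 3 (0.28 log units; within the scatter). Compound 3 is estimated at 55 nM, range 18 nM to 200 nM.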

Compound 3, half-maximal inhibitory concentration: 1900 nM
Estimate against measurement, compound 3: 35-fold (1.54 log units) below; the whole stated range lies below it.
By their numbers in this assay, from the lowest: compounds 1 and 2 (each within the scatter of the next); then compound 3.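

Where the hydroxyl sits on the phenyl matters in this assay after all. The step of a 66-fold higher number from compound 2 to compound 3 (1.82 log units; beyond the scatter) and the step of a 90-fold higher number from compound 1 to compound 3 (1.96 log units; beyond the scatter) are both large, whereas 3-hydroxyphenyl and 4-hydroxyphenyl lie within the scatter of each other, and the entering and leaving groups have the same atoms and the same counted donors and acceptors. Nothing available explains this loss.

Open, from the compounds shown here alone, is whether the loss belongs to the hydroxyl itself, which a methoxy or an amine in its place on the 2-hydroxyphenyl would test. Also open, going by these compounds, is how a plain phenyl compares with all three.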